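From ethyl to allyl: what compound 4 may do

The source may report more compounds than this note shows. Statements on the series, on what has been measured and on what is new or still open speak of the compounds shown alone.

Among the measured compounds shown here, in a functional assay on HepG2 cells (Homo sapiens) for cytotoxicity, read by sulforhodamine B assay, with a stated time of 48 h (on this read-out higher numbers stand for weaker inhibition and lower numbers for stronger inhibition), compound 3 `CCn1c(-c2ccc(Cl)cc2)cc(-c2ccc(Cl)cc2)c(C#N)c1=O` gives 22.3 ug/mL, the highest number so far and thus the weakest inhibition. Compound 1 `N#Cc1c(-c2ccc(Cl)cc2)cc(-c2ccc(Cl)cc2)n(C(=O)c2ccccc2)c1=O` gives 3.75 ug/mL and compound 2 `N#Cc1c(-c2ccc(Cl)cc2)cc(-c2ccc(Cl)cc2)n(CC(O)CCl)c1=O` gives 4.8 ug/mL, values within the scatter of each other. Compound 4 `C=CCn1c(-c2ccc(Cl)cc2)cc(-c2ccc(Cl)cc2)c(C#N)c1=O` has vinyl in place of methyl on a saturated chain carbon bound to an aromatic nitrogen, turning ethyl into allyl: vinyl in place of methyl on a saturated chain carbon bound to an aromatic nitrogen. The relevant evidence comes from changes on that same nitrogen. Two were modest, a 5.9-fold higher number from compound 1 to compound 3 (0.77 log units; beyond the scatter) and a 4.6-fold higher number from compound 2 to compound 3 (0.67 log units; beyond the scatter), while a 1.3-fold higher number from compound 1 to compound 2 (0.11 log units; within the scatter) stayed within the scatter. None compares groups as alike as ethyl and allyl, so only a small shift, perhaps downward in this assay, is expected. The expected change is a 1.4-fold lower number from compound 3 to compound 4 (0.14 log units; within the scatter). For compound 4 the estimated value is 16 ug/mL, with a range of 7 ug/mL to 35 ug/mL.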

Compound 4, half-maximal inhibitory concentration: 20 ug/mL
Estimate against measurement, compound 4: 1.3-fold (0.10 log units) below; the measured number falls inside the stated range.
By their numbers in this assay, from the lowest: compounds 1 and 2 (each within the scatter of the next); then compounds 4 and 3 (each within the scatter of the next).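

In this assay, among the compounds shown here, vinyl in place of methyl on a saturated chain carbon bound to an aromatic nitrogen gives a 1.1-fold lower number from compound 3 to compound 4 (0.05 log units; within the scatter) and so leaves compound 3 and compound 4 indistinguishable, the first direct comparison of ethyl with allyl. Allyl, like ethyl, stands apart from the other two groups, with a 4.2-fold higher number from compound 2 to compound 4 (0.62 log units; beyond the scatter) and a 5.3-fold higher number from compound 1 to compound 4 (0.73 log units; beyond the scatter) showing that both 3-chloro-2-hydroxypropyl and benzoyl give clearly stronger inhibition. No measured property is available to explain these gaps. Still open, on these data alone, is whether a longer chain such as butyl, or a chain ending in an amine, would group with ethyl and allyl or with benzoyl and 3-chloro-2-hydroxypropyl.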